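The source may hold more compounds than are shown below. What is called first, only, known or untested is meant among the compounds shown, and "the series" means these compounds.

Measured in a functional assay on MCF7 cells (Homo sapiens) for antiproliferative activity, read by sulforhodamine B assay, with a stated time of 48 h; a higher number here means a weaker inhibitor, a lower number a stronger inhibitor:
- compound 1 `COc1cccc(C2=NN(c3ccccc3)C(c3ccc(Br)cc3)C2O)c1`: 11 nM
- compound 2 `COc1cccc(C2=NNC(c3ccc(Cl)cc3)C2O)c1`: 49 nM

Of these two compounds, compound 2 stands at the higher number, with 49 nM. Compound 1 gives the lower number, 11 nM, and the gap between them lies beyond the scatter.

The next compound to be tested is compound 3 `COc1cccc(C2=NN(c3ccccc3)C(c3ccc(Cl)cc3)C2O)c1`. It departs from compound 2 by a single change: phenyl in place of hydrogen on an amine nitrogen in a ring. This places phenyl in place of hydrogen on an amine nitrogen in a ring, while the 4-chlorophenyl group stays as it is.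

Going by the values given here, no measured pair shows this change alone, so the expectation rests on one comparison. Compound 1 also bears phenyl at that place and gives 11 nM, although it holds bromine where compound 3 holds chlorine. A lower number than that of compound 2 is therefore expected in this assay, by a step beyond the scatter.

The expected change is a 3.3-fold lower number from compound 2 to compound 3 (0.51 log units; beyond the scatter).

For compound 3 the estimated value is 15 nM, with an expected range from 6 nM to 40 nM.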

Compound 3, half-maximal inhibitory concentration: 9.7 nM
Compound 3: the middle estimate sits 1.5-fold (0.19 log units) above what was measured; measured number inside the range.
By their numbers in this assay, from the lowest: compounds 3 and 1 (each within the scatter of the next); then compound 2.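

In this assay, going by these compounds alone, phenyl in place of hydrogen on the amine nitrogen in a ring gives a 5.1-fold lower number from compound 2 to compound 3 (0.70 log units; beyond the scatter) with the 4-chlorophenyl group held constant, so this step shows the effect of that change alone, which the earlier compounds could not do. Chloro in place of bromo on an aromatic carbon gives a 1.1-fold lower number from compound 1 to compound 3 (0.05 log units; within the scatter) on the same phenyl-bearing scaffold, a step within the scatter, so this assay does not tell these two halogens apart in this pair. Within the data shown here, of the two changes that separate the earlier compounds, only the one on the ring nitrogen therefore gives a step beyond the scatter, although each rests on a single pair, and no measurement at hand accounts for the effect of phenyl at this position.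

Hydrogen and phenyl are the only groups shown on this nitrogen, so it remains open how methyl, benzyl or a substituted ring such as 4-methoxyphenyl would compare there. The hydroxy group and the 3-methoxyphenyl group stay the same throughout, which leaves open what a carbonyl at the first place or an unsubstituted phenyl at the second would do.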